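Chain length and sigma receptor binding in a chromone series

The source may report more compounds than this note shows. Statements on the series, on what has been measured and on what is new or still open speak of the compounds shown alone.

Measured so far:
compound 1 `CN(C)CCCCOc1ccc2oc(-c3ccccc3)cc(=O)c2c1`, 720 nM in an assay on isolated protein (Cavia porcellus) with Sigma non-opioid intracellular receptor 1 (Homo sapiens) as the target, read by radioligand binding; a higher number here means a weaker inhibitor, a lower number a stronger inhibitor
compound 2 `CN(C)CCCCCCOc1ccc2oc(-c3ccccc3)cc(=O)c2c1`, 432 nM
compound 3 `CN(C)CCCCCCCCOc1ccc2oc(-c3ccccc3)cc(=O)c2c1`, 227 nM

Compound 3 stands at the low end of the three numbers: a 3.2-fold lower number from compound 1 to compound 3 (0.50 log units; beyond the scatter), whereas a 1.9-fold lower number from compound 2 to compound 3 (0.28 log units; within the scatter). Compound 4 `CN(C)CCCCCCCCCCOc1ccc2oc(-c3ccccc3)cc(=O)c2c1` carries the next extension of the same kind: 2-(dimethylamino)ethyl in place of dimethylamino on a saturated chain carbon, eight bonds along the chain from an oxygen on an aromatic ring. The two earlier extensions bear directly on it; a 1.7-fold lower number from compound 1 to compound 2 (0.22 log units; within the scatter) and a 1.9-fold lower number from compound 2 to compound 3 (0.28 log units; within the scatter), each small on its own, yet together adding up to the larger gap from compound 1 to compound 3. Going by the values given here, no compound in the set breaks this run, but the set is only three. The expected step for compound 4 is therefore a modest further fall, a 1.5-fold lower number from compound 3 to compound 4 (0.18 log units; within the scatter), not necessarily beyond the scatter. Compound 4 is estimated at 150 nM, within 70 nM to 350 nM.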

Compound 4, half-maximal inhibitory concentration: 297 nM
Compound 4: the middle estimate sits 2.0-fold (0.30 log units) below what was measured, and the stated range covers the measured number.
By their numbers in this assay, from the lowest: compounds 3, 4, 2 and 1 (each within the scatter of the next, the first and the last beyond it).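

The 2-(dimethylamino)ethyl extension, eight bonds along the chain from an oxygen on an aromatic ring, brings no further fall in this assay: a 1.3-fold higher number from compound 3 to compound 4 (0.12 log units; within the scatter). The gap to the start of the series persists, a 2.4-fold lower number from compound 1 to compound 4 (0.38 log units; beyond the scatter), whereas a 1.5-fold lower number from compound 2 to compound 4 (0.16 log units; within the scatter) shows no separation. This extension cannot be told apart from the same change made four bonds along the chain: the same change on two cores in this assay, a 1.7-fold lower number (0.22 log units; within the scatter) from compound 1 to compound 2 and a 1.3-fold higher number (0.12 log units; within the scatter) from compound 3 to compound 4, 2.2-fold (0.34 log units) apart, within the scatter of two such steps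

From the compounds shown here alone, whether the numbers level off or turn upward stays open, as does how a longer chain would read. Also open, going by these compounds, is what a piperidine in place of the dimethylamino end would do.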